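Cytotoxicity of Compound 3 Expected to Stay Beyond the Limit

A few compounds are considered here, and "the series" means these few. Any claim that something is new, unique, unknown or untested is made for them only; others in the source may bear on it.

Compound 1 `O=[N+]([O-])c1cc(CSc2nnnn2C2CCCCC2)cc([N+](=O)[O-])c1`: in an ADME assay on HepG2 cells (Homo sapiens) for cytotoxicity, read by MTT assay, with a stated time of 48 h (a lower number here means a stronger inhibitor, a higher number a weaker inhibitor), compound 1 gives > 30000 nM, which is a limit of the assay rather than a number.
Compound 2 `COc1ccc(-n2nnnc2SCc2cc([N+](=O)[O-])cc([N+](=O)[O-])c2)cc1`: in this assay compound 2 gives > 30000 nM, likewise a limit.

Compound 2 thus stands at the limit of > 30000 nM in this assay, at which 2 of the 2 values shown sit, and the step that the two limits leave unreadable from compound 1 to compound 2. Compound 3 `O=[N+]([O-])c1cc(CSc2nnnn2-c2ccc(Cl)c(Cl)c2)cc([N+](=O)[O-])c1` differs from compound 2 by 3,4-dichlorophenyl in place of 4-methoxyphenyl on an aromatic nitrogen. Within the data shown here, no readable measured step bears on this change, since the only step available is unreadable. Compound 3 is therefore expected to remain at the limit, with a step that the limit leaves unreadable from compound 2 to compound 3 estimated as no change beyond the scatter. The estimate for compound 3 in this assay is 40000 nM, ranging from 12000 nM to 130000 nM.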

Compound 3, half-maximal inhibitory concentration: 26000 nM
Compound 3: middle estimate off by 1.5-fold (0.19 log units), on the high side; measured number inside the range.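

In this assay, the 3,4-dichlorophenyl group on the aromatic nitrogen gives the only readable number among the compounds shown, with an at least 1.1-fold lower number from compound 2 to compound 3 (0.06 log units; that floor lies within the scatter). Against the cyclohexyl group, the same position shows an at least 1.1-fold lower number from compound 1 to compound 3 (0.06 log units; that floor lies within the scatter), so neither floor establishes a change beyond the scatter. The other two compounds remain at a limit of the assay: the limit of > 30000 nM in this assay, at which 2 of the 3 values shown sit.

On these data alone, how far compound 1 and compound 2 truly lie from compound 3 stays open. So does whether an amine or a carboxylic acid on this nitrogen's aromatic substituent would move the number further.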